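The source may hold more compounds than are shown below. What is called first, only, known or untested is meant among the compounds shown, and "the series" means these compounds.

Measured compounds:
- compound 1 `Cc1cc(-c2ccccc2)n(/C(N)=N/S(=O)(=O)c2cc(C)c(Cl)cc2SCc2cccc3ccccc23)n1`, which in a functional assay on HCT-116 cells (Homo sapiens) for cytotoxicity, read by MTT assay, with a stated time of 72 h (a higher number here means a weaker inhibitor, a lower number a stronger inhibitor), gives 7000 nM
- compound 2 `Cc1ccc(CSc2cc(Cl)c(C)cc2S(=O)(=O)/N=C(\N)n2nc(C)cc2-c2ccccc2)cc1`, which in this assay gives 28000 nM
- compound 3 `Cc1cc(S(=O)(=O)/N=C(\N)n2nccc2-c2ccccc2)c(SCc2ccc(C(F)(F)F)cc2)cc1Cl`, which in this assay gives 14000 nM

Compound 2 carries the highest of the three numbers in this assay. Its gap to compound 3 is within the usual scatter, so the two cannot be put in order; only compound 1 sits clearly apart, as the step of a 4.0-fold higher number from compound 1 to compound 2 (0.60 log units; beyond the scatter) shows. Among the compounds with values here, that step swaps the whole group on the saturated chain carbon bound to sulfur, naphthalen-1-yl for 4-methylphenyl, and it is the only measured step that touches this part of the molecule.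

Compound 4 `Cc1cc(-c2ccccc2)n(/C(N)=N/S(=O)(=O)c2cc(C)c(Cl)cc2SCc2ccccc2)n1` differs from compound 2 by a much smaller change: hydrogen in place of methyl on an aromatic carbon. Compound 3 also carries a different group at this position, but it differs from compound 2 elsewhere too, so its value and that of compound 2 show only that both lie high and within scatter of each other.

Nothing measured here tells how loss of a single methyl, placed para to a large group, moves the number. Within the data shown here, the only related step is the larger swap from compound 1 to compound 2, and a step of one heavy atom is expected to be smaller than that, most likely within the scatter in either direction. Compound 4 is therefore expected to give about 20000 nM in this assay, between 8000 nM and 50000 nM, an expected step of a 1.4-fold lower number from compound 2 to compound 4 (0.15 log units; within the scatter).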

Compound 4, half-maximal inhibitory concentration: 10000 nM
For compound 4 the middle estimate is 2.0-fold (0.30 log units) above the measured one, and the stated range covers the measured number.
By their numbers in this assay, from the lowest: compounds 1, 4, 3 and 2 (each within the scatter of the next, the first and the last beyond it).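

In this assay, a single carbon on this ring matters: hydrogen in place of methyl, para to a large group, gives a 2.8-fold lower number from compound 2 to compound 4 (0.45 log units; beyond the scatter) and so turns 4-methylbenzyl into benzyl with a change larger than the usual scatter. The new compound also changes how the earlier step reads, since phenyl in place of naphthalen-1-yl gives a 1.4-fold higher number from compound 1 to compound 4 (0.15 log units; within the scatter) and leaves those two compounds without an order, so the earlier 4.0-fold higher number from compound 1 to compound 2 (0.60 log units; beyond the scatter) need not reflect the loss of the larger naphthalen-1-yl group and among these three compounds only the one carrying the methyl stands apart. No measurement shown here explains why this one methyl moves the number.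

Compound 3 carries trifluoromethyl on this ring but also differs elsewhere, so its steps to the other compounds cannot be read. Going by these compounds, what remains open is whether the change follows from methyl alone or would also appear with another group in the same place, such as chlorine, methoxy, an ethyl chain or an amine.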